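Aryl ketone variation on a thymidine succinate series

A few compounds are considered here, and "the series" means these few. Any claim that something is new, unique, unknown or untested is made for them only; others in the source may bear on it.

Measured in a functional assay on SMMC-7721 cells (Homo sapiens) for antiproliferative activity, read by MTT assay, with a stated time of 48 h; on this read-out higher numbers stand for weaker inhibition and lower numbers for stronger inhibition:
compound 1 `COc1cccc(C(=O)c2ccc(OC)c(OC(=O)CCC(=O)OC[C@@H]3C=C[C@H](n4cc(C)c(=O)[nH]c4=O)O3)c2)c1` gives 820 nM
compound 2 `COc1ccc(C(=O)c2cccc(Cl)c2)cc1OC(=O)CCC(=O)OC[C@@H]1C=C[C@H](n2cc(C)c(=O)[nH]c2=O)O1` gives 3210 nM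
compound 3 `COc1ccc(C(=O)c2ccc([N+](=O)[O-])cc2)cc1OC(=O)CCC(=O)OC[C@@H]1C=C[C@H](n2cc(C)c(=O)[nH]c2=O)O1` gives 30500 nM

Compound 3 stands at the highest number of the three; the steps of a 37-fold higher number from compound 1 to compound 3 (1.57 log units; beyond the scatter) and a 9.5-fold higher number from compound 2 to compound 3 (0.98 log units; beyond the scatter) both lead up to it and both lie beyond the scatter. Compound 4 `COc1cc(OC)c(C(=O)c2ccc(OC)c(OC(=O)CCC(=O)OC[C@@H]3C=C[C@H](n4cc(C)c(=O)[nH]c4=O)O3)c2)cc1OC` differs from compound 3 in one place: 2,4,5-trimethoxyphenyl in place of 4-nitrophenyl on a carbonyl carbon. The two steps above bear on this change, since each replaced an aryl ring carrying a methoxy or a chloro with the nitrophenyl, and the methoxy-bearing ring of compound 1 gave the lowest number. Reversing that exchange, with three methoxy groups now entering, a large step downward in this assay is expected, a 25-fold lower number from compound 3 to compound 4 (1.41 log units; beyond the scatter). Compound 4 is accordingly estimated at about 1200 nM, with a range from 300 nM to 5000 nM.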

Compound 4, half-maximal inhibitory concentration: 2860 nM
Compound 4: middle estimate off by 2.4-fold (0.38 log units), on the low side; measured number inside the range.
By their numbers in this assay, from the lowest: compound 1; then compounds 4 and 2 (each within the scatter of the next); then compound 3.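

Working notes: in this assay the 2,4,5-trimethoxyphenyl ring on this carbonyl carbon sits far from the 4-nitrophenyl result (an 11-fold lower number from compound 3 to compound 4 (1.03 log units; beyond the scatter)), so a ring with three methoxy groups is accepted here. More methoxy groups do not simply give lower numbers: the change from the 3-methoxyphenyl ring gives a 3.5-fold higher number from compound 1 to compound 4 (0.54 log units; beyond the scatter) and the change from the 3-chlorophenyl ring gives a 1.1-fold lower number from compound 2 to compound 4 (0.05 log units; within the scatter) and stays within the scatter. No available evidence accounts for these differences. Still open, going by these compounds, is how an aryl ring carrying an amine or a carboxylic acid on this carbonyl carbon would compare with compound 1.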